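This account rests on a few compounds, and the source may have more. Where it says the series, first, only, none or still open, it means among the compounds named here.

Measured in a functional assay on HepG2 cells (Homo sapiens) for inhibition, read by MTT assay, with a stated time of 48 h; on this read-out lower numbers stand for stronger inhibition and higher numbers for weaker inhibition:
compound 1 `CCc1ccc(-c2nc3ccccn3c2Sc2ccccc2)cc1` gives 50200 nM
compound 2 `c1ccc(Sc2c(-c3cccs3)nc3ccccn23)cc1` gives 17100 nM

Going by the values given here, compound 2 at 17100 nM holds the lower of the two numbers so far, with compound 1 above it. Among the compounds with values here, the one measured step is a 2.9-fold lower number from compound 1 to compound 2 (0.47 log units; beyond the scatter) and it is modest. That step swaps thiophen-2-yl in place of 4-ethylphenyl, a different change from the one now in question, so it bears only loosely on it.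

Compound 3 `Clc1ccc(Sc2c(-c3cccs3)nc3ccccn23)cc1` is compound 2 with chloro in place of hydrogen on an aromatic carbon, para to a large group chloro in place of hydrogen on an aromatic carbon and thus phenyl to 4-chlorophenyl. Within the data shown here, no measured step covers this change. In this assay a step no larger than the modest one above is expected, probably none beyond the scatter, with a slight lean towards a lower number. The expected step is a 1.3-fold lower number from compound 2 to compound 3 (0.12 log units; within the scatter) and nothing more is claimed for it. Compound 3 is estimated at 13000 nM (5000 nM to 35000 nM).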

Compound 3, half-maximal inhibitory concentration: 59300 nM
Beside the measured number, compound 3's estimate is 4.6-fold (0.66 log units) below it, and the stated range ends below it.
By their numbers in this assay, from the lowest: compound 2; then compounds 1 and 3 (each within the scatter of the next).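

In this assay, going by these compounds alone, the first measured change on the phenyl group of compound 2 is phenyl to 4-chlorophenyl, and it gives a 3.5-fold higher number from compound 2 to compound 3 (0.54 log units; beyond the scatter), a modest step beyond the scatter towards weaker inhibition. A single chlorine atom, para to a large group, is therefore enough to shift the read-out, so this place on the series is not silent to substitution. No measurement at hand bears on the reason for this step.

Still open, as far as these compounds go, is whether the higher number belongs to chloro alone or extends to other groups at this place, such as fluoro, methoxy, an amine or a carboxylic acid. Also open, from the compounds shown here alone, is whether chloro has a similar effect when 4-ethylphenyl stands in place of thiophen-2-yl.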